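Swapping the Five-Membered Ring on a Shared Core

This account rests on a few compounds, and the source may have more. Where it says the series, first, only, none or still open, it means among the compounds named here.

Three compounds share one core and differ only in the aromatic group attached to it. Compound 1 `Cc1cccc(-c2ccccc2OCC2=NCCN2)n1` was tested in a functional assay for activation of Alpha-1D adrenergic receptor (Homo sapiens), read by calcium flux; on this read-out higher numbers stand for an effect only at larger amounts of compound and lower numbers for an effect already at smaller amounts. For compound 1 the result is a limit of the assay, < 100000 nM, and not a number. Compound 2 `c1ccc(-c2ccncn2)c(OCC2=NCCN2)c1` likewise gives only a limit, < 100000 nM. Within the data shown here, compound 3 `c1csc(-c2ccccc2OCC2=NCCN2)c1` is the single compound with a measured number: in this assay compound 3 gives 15.9 nM, so it stands as the one readable value among the three. Among the measured compounds shown here, the only step joining two measured compounds, a step that the limit leaves unreadable from compound 2 to compound 3, cannot be sized, since (the limit of < 100000 nM in this assay, at which 2 of the 3 values shown sit).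

The next compound, compound 4 `Cc1cc(-c2ccccc2OCC2=NCCN2)sn1`, differs from compound 3 in one place: 3-methyl-1,2-thiazol-5-yl in place of thiophen-2-yl on an aromatic carbon. No measured step bears on this change; the one step shown runs into a limit, and the two limit compounds carry other groups. The data therefore give no direction for this change. Since compound 3 gives 15.9 nM and the entering group keeps a five-membered aromatic ring on the same carbon, compound 4 is expected to stay a readable number, with a step estimated as a 3.1-fold higher number from compound 3 to compound 4 (0.50 log units; beyond the scatter). The estimate for compound 4 is 50 nM, between 10 nM and 300 nM.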

Compound 4, half-maximal effective concentration: < 100000 nM
Compound 4: no number, only a limit; the forecaster's own chance of this, stated with the estimate: 10%; the middle value lies beyond the limit too.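

For compound 4 the result < 100000 nM is a limit of the assay and not a number. The steps to compound 4 from compound 3 and from compound 2 therefore cannot be read: the limit of < 100000 nM in this assay, at which 3 of the 4 values shown sit.

Left open is how 3-methyl-1,2-thiazol-5-yl compares with thiophen-2-yl in this assay and whether thiophen-2-yl is alone in giving a readable number on this core.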